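The source may hold more compounds than are shown below. What is called first, only, known or untested is meant among the compounds shown, and "the series" means these compounds.

Compound 1, `CC(=O)OC/C(=C\C1CCCCC1)C(=O)c1ccccc1`, was tested in a functional assay on T47D cells (Homo sapiens) for inhibition, read by sulforhodamine B assay, with a stated time of 48 h (on this read-out lower numbers stand for stronger inhibition of growth and higher numbers for weaker inhibition of growth), where compound 1 gives 22000 nM. Compound 2, `CC(=O)OC/C(=C\C1CCCCC1)C(=O)c1ccc(Cl)cc1`, differs from compound 1 by one change, (chloro in place of hydrogen on an aromatic carbon), and in this assay compound 2 gives 18000 nM. That change made a 1.2-fold lower number from compound 1 to compound 2 (0.09 log units; within the scatter), so the two numbers cannot be told apart. Compound 3, `CC(=O)OC/C(=C/c1ccccc1Cl)C(=O)c1ccccc1`, is built on a different core; the difference between the core of compound 1 and the core of compound 3 is not broken down here. In this assay compound 3 gives 19000 nM, a value within the scatter of both other compounds, so no order among the three can be claimed.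

Compound 4, `CC(=O)OC/C(=C/c1ccc(Cl)cc1Cl)C(=O)c1ccccc1`, has not yet been measured. It differs from compound 3 by chloro in place of hydrogen on an aromatic carbon. Going by the values given here, this is the same kind of change as the one from compound 1 to compound 2, although the surroundings are not identical: in compound 2 the new chloro sits para to a large group, whereas in compound 4 it sits meta to a chloro group (1 heavy atom) and para to a large group. The earlier like-for-like change gave a 1.2-fold lower number from compound 1 to compound 2 (0.09 log units; within the scatter). On that basis only a small step is expected, namely a 1.3-fold lower number from compound 3 to compound 4 (0.10 log units; within the scatter). For compound 4 the expected value in this assay is 15000 nM, with the likely range running from 7000 nM to 35000 nM.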

Compound 4, concentration for 50% growth inhibition: 20000 nM
Compound 4: the middle estimate sits 1.3-fold (0.12 log units) below what was measured; the range from low to high includes it.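

In this assay, putting a chloro on the aromatic ring of compound 3, where it sits meta to the chloro group already there, gave a 1.1-fold higher number from compound 3 to compound 4 (0.02 log units; within the scatter), so the two numbers cannot be told apart and the added chlorine changed nothing that can be read. Set beside the earlier case, the same swap of hydrogen for chloro gives a matching answer on both cores, with no difference that can be separated from ordinary assay noise: the same change on two cores in this assay, a 1.2-fold lower number (0.09 log units; within the scatter) from compound 1 to compound 2 and a 1.1-fold higher number (0.02 log units; within the scatter) from compound 3 to compound 4, 1.3-fold (0.11 log units) apart, within the scatter of two such steps. This shows that, in these two pairs, the step carried over from one core to the other in the sense that neither produced a readable change, but it does not show that chloro has no effect in general, since two small steps on two cores make no rule for other cores or for other places on the ring.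

Still open, as far as these compounds go, is whether a different kind of group on the aromatic ring, such as an amine or a carboxylic acid, would move the number clearly beyond the scatter. Also open is whether a longer chain in place of the acetyl part of these compounds would do so.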